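Replacing the 3,3-dimethyloxiran-2-yl group of compound 2

The compounds below may be only part of what the source reports. "The series", "measured", "known", "first", "only" and "open" are said of these compounds alone.

Of the compounds shown here, two have so far been tested in an ADME assay on HEK293 cells (Homo sapiens) for cytotoxicity, with a stated time of 72 h; a lower number here means that less compound is needed, a higher number that more compound is needed for the effect. Compound 1 `C=C[C@@](C)(/C=C/c1ccc(OCc2ccccc2)cc1)CCC=C(C)C` gives > 36600 nM, which is a limit of the assay and not a number. Compound 2 `C=C[C@@](C)(/C=C/c1ccc(O)cc1)CCC1OC1(C)C` gives > 36600 nM, which is likewise only a limit. The record so far is thus (the limit of > 36600 nM in this assay, at which 2 of the 2 values shown sit), and compound 2 has no exact value to stand on.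

Compound 3 `C=C[C@@](C)(/C=C/c1ccc(O)cc1)CC/C=C(C)/C=N/N` has not yet been measured. It differs from compound 2 by one change: a group of 6 heavy atoms (4 carbon, 2 nitrogen; no ring) in place of a group of 5 heavy atoms (4 carbon, 1 oxygen; one three-membered non-aromatic ring with 1 hetero atom), on a saturated chain carbon, three bonds along the chain from two double-bonded chain carbons. The three-membered ring is gone, and two double bonds outside aromatic rings come in.

Among the compounds with values here, no measured step is available as a guide, so the expectation rests on the limit of compound 2 at > 36600 nM. A small move toward a lower number is expected, perhaps none beyond the scatter, and the assay may well report only a limit again. The estimated step is an at least 1.2-fold lower number from compound 2 to compound 3 (0.08 log units; that floor lies within the scatter). In this assay compound 3 is estimated at 30000 nM, with an expected range from 12000 nM to 40000 nM.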

Compound 3, half-maximal effective concentration: > 36600 nM
Compound 3 gave a limit, no number; the forecaster's own chance of this, stated with the estimate: 70%; middle value at least 1.2-fold (0.08 log units) away from the limit.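

In this assay, within the data shown here, compound 3 gives > 36600 nM, which is a limit and not a number, as is the result for compound 2, so no step between compound 2 and compound 3 can be read. The compounds shown leave open whether replacing the 3,3-dimethyloxiran-2-yl group changes this read-out at all, as the record holds no exact value: the limit of > 36600 nM in this assay, at which 3 of the 3 values shown sit.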